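Swapping a Dichlorophenyl for a Methoxyphenyl on a Benzylamine

The source may report more compounds than this note shows. Statements on the series, on what has been measured and on what is new or still open speak of the compounds shown alone.

Compound 1 `Nc1cc(N)c2nc(-c3ccccc3)c(Oc3ccc(Cl)c(Cl)c3)nc2c1` gives 16200 nM in a functional assay on LOX IMVI cells (Homo sapiens) for inhibition, read by sulforhodamine B assay, with a stated time of 48 h; on this read-out higher numbers stand for weaker inhibition of growth and lower numbers for stronger inhibition of growth.
Compound 2 `Nc1cc(N)c2nc(-c3ccccc3)c(NCc3ccc(Cl)c(Cl)c3)nc2c1` gives 2140 nM in this assay.
Compound 3 `CCOC(=O)[C@H](CCC(=O)O)NC(=O)c1ccc(Oc2nc3cc(N)cc(N)c3nc2-c2ccccc2)cc1` gives 12000 nM in this assay.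

All three share one core and differ only in the group hanging from it. In this assay compound 2 stands lowest of the three numbers; compound 3 lies beyond the scatter above it, and compound 1 further still. Compound 4 `COc1ccc(CNc2nc3cc(N)cc(N)c3nc2-c2ccccc2)cc1` has not been measured. It differs from compound 2 in one place: 4-methoxyphenyl in place of 3,4-dichlorophenyl on a saturated chain carbon bound to a nitrogen on an aromatic ring. Among the measured compounds shown here, no measured pair shows this particular swap, so nothing here tells how large its effect is. Compound 4 is expected to be modestly weaker, with an estimated step of a 2.3-fold higher number from compound 2 to compound 4 (0.37 log units; beyond the scatter) that may just pass the scatter. The estimate for compound 4 is 5000 nM, within a range from 1500 nM to 16000 nM.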

Compound 4, concentration for 50% growth inhibition: 13500 nM
Compound 4: middle estimate off by 2.7-fold (0.43 log units), on the low side; measured number inside the range.
By their numbers in this assay, from the lowest: compound 2; then compounds 3, 4 and 1 (each within the scatter of the next).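

Among the compounds shown here, this is the first direct reading of a change at this position: in this assay, 4-methoxyphenyl in place of 3,4-dichlorophenyl gives a 6.3-fold higher number from compound 2 to compound 4 (0.80 log units; beyond the scatter), so growth inhibition here depends on what the benzyl group carries. Weaker inhibition follows this swap, and the step lies beyond the scatter. Nothing at hand says why the number rises.

Going by these compounds, whether the chlorines leaving or the methoxy entering drives the step stays open. A plain phenyl or a 4-chlorophenyl in the same place would help separate the two.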